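The source may report more compounds than this note shows. Statements on the series, on what has been measured and on what is new or still open speak of the compounds shown alone.

Values in a functional assay on VCaP cells (Homo sapiens) for antiproliferative activity, read by CCK-8 assay, with a stated time of 6 days; a lower number here means a stronger inhibitor, a higher number a weaker inhibitor:
Compound 1 `CCN(c1cccc(-c2ccccc2)c1)c1ccc(C#N)c(Cl)c1`: "not determined" (no result reported)
Compound 2 `N#Cc1ccc(N2CCc3cc(-c4cnc5ccccc5c4)ccc32)cc1C(F)(F)F`: "not determined" (no result reported)
Compound 3 `CCN(c1ccc(C#N)c(Cl)c1)c1cc(-c2ccccc2)ccc1C`: > 30000 nM

The record of this small set is thin. Neither compound 1 nor compound 2 yielded a result, so only one entry of the three carries any reading at all. In this assay compound 3 gives > 30000 nM, and this is a limit of the assay, not a number. The whole measured picture therefore comes down to the limit of > 30000 nM in this assay, at which 1 of the 3 values shown sits.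

The next compound to be tested is compound 4 `CCN(c1ccc(C#N)c(Cl)c1)c1cc(-n2cccn2)ccc1C`. It keeps the shared core of compound 3 and carries 1H-pyrazol-1-yl in place of phenyl on an aromatic carbon, meta to a large group and para to a methyl group: 1H-pyrazol-1-yl in place of phenyl on an aromatic carbon.

Going by the values given here, no measured step in this set shows what such an exchange does, so any expectation is loose. A moderate move toward stronger inhibition is the expected outcome, estimated as an at least 3.0-fold lower number from compound 3 to compound 4 (0.47 log units; beyond the scatter), and a second reading at the limit would be no surprise. For compound 4 the expected value is 10000 nM, with an estimated range from 2000 nM to 30000 nM.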

Compound 4, half-maximal inhibitory concentration: 2340 nM
Estimate against measurement, compound 4: 4.3-fold (0.63 log units) above; the measured number falls inside the stated range.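

In this assay, the exchange of phenyl for 1H-pyrazol-1-yl on the aromatic carbon, meta to a large group and para to a methyl group, gives an at least 12-fold lower number from compound 3 to compound 4 (1.10 log units; beyond the scatter). Going by these compounds alone, this is the only readable step in the set, and it shows that the group at this place can decide whether the series gives a numerical reading at all. Within the data shown here, the exchange swaps a six-membered aromatic ring of carbon only for a five-membered aromatic ring with 2 hetero atoms, and the single pair cannot separate the change in ring size from the entry of the nitrogen atoms. The true size of the step stays open, since one end of it is a limit of the assay and not a number: the limit of > 30000 nM in this assay, at which 1 of the 4 values shown sits.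

The compounds shown leave open whether a 1H-imidazol-1-yl group, a pyridinyl ring or a simple amine at the same place would lower the number further or lose the gain. They also do not tell whether the methyl group or the ethyl chain on the shared core contributes to the reading of compound 4.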